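Working notes: end-group change at compound 2

The compounds below may be only part of what the source reports. "The series", "measured", "known", "first", "only" and "open" are said of these compounds alone.

- compound 1 `COc1cc(/C=C/C(=O)/C=C/c2cccc3ccccc23)ccc1OCc1cn(CCOc2cc(=O)oc3ccccc23)nn1`: 20%
- compound 2 `COc1cc(/C=C/C(=O)/C=C/c2ccco2)ccc1OCc1cn(CCOc2cc(=O)oc3ccccc23)nn1`: 14%

In a functional assay on PC-3 cells (Homo sapiens) for inhibition, read by sulforhodamine B assay, with a stated time of 48 h, tested at 50 uM (a higher number here means more inhibition of growth at the concentration tested, a lower number less inhibition of growth), compound 2 gives 14%, within the scatter of compound 1. Compound 3 `COc1ccc(/C=C/C(=O)/C=C/c2ccc(OCc3cn(CCOc4cc(=O)oc5ccccc45)nn3)c(OC)c2)cc1` has 4-methoxyphenyl in place of furan-2-yl on a double-bonded chain carbon bound to a double-bonded chain carbon. Among the compounds with values here, one measured step bears on this place, a number 6 percentage points lower from compound 1 to compound 2 (within the scatter), where furan-2-yl replaced naphthalen-1-yl. Within the data shown here, with only that step as a guide, no change beyond the scatter is expected in this assay. The expected step is a number 3 percentage points higher from compound 2 to compound 3 (within the scatter). For compound 3 the estimated value is 17%, with an expected range of 8% to 30%.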

Compound 3, percent growth inhibition at one concentration: 15%
Compound 3: middle estimate off by 2 percentage points, on the high side, and the stated range covers the measured number.
By their numbers in this assay, from the lowest: compounds 2, 3 and 1 (each within the scatter of the next).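

In this assay the 4-methoxyphenyl group gives a number 1 percentage points higher from compound 2 to compound 3 (within the scatter) and a number 5 percentage points lower from compound 1 to compound 3 (within the scatter), so a six-membered aromatic ring of carbon only with a methoxy group joins furan-2-yl and naphthalen-1-yl without separating from either. At this position, all three aromatic end groups now lie within the scatter of one another. No measured evidence accounts for this result.

Going by these compounds, whether an end group carrying an amine or a carboxylic acid at this place would give a step beyond the scatter remains open.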